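Swapping a trifluoroethyl amide for a trifluoromethylpyridyl amide

The source may hold more compounds than are shown below. What is called first, only, known or untested is meant among the compounds shown, and "the series" means these compounds.

Measured compounds:
Compound 1 `COC(=O)c1ccccc1-c1ccc(CNC(=O)C2(NC(=O)c3cncnc3)CC2)cc1`: 25.5 nM
Compound 2 `COC(=O)c1ccccc1-c1ccc(CNC(=O)C2(NC(=O)CC(F)(F)F)CC2)cc1`: 63 nM

In an assay on CHO cells for binding affinity to B1 bradykinin receptor (Homo sapiens) (a lower number here means a stronger inhibitor, a higher number a weaker inhibitor), compound 2 gives the highest of the two numbers; its nearest neighbour is compound 1, which gives 25.5 nM. Compound 3 `COC(=O)c1ccccc1-c1ccc(CNC(=O)C2(NC(=O)c3cncc(C(F)(F)F)c3)CC2)cc1` differs from compound 2 by 5-(trifluoromethyl)pyridin-3-yl in place of 2,2,2-trifluoroethyl on a carbonyl carbon. Going by the values given here, the only step that bears on this is a 2.5-fold higher number from compound 1 to compound 2 (0.39 log units; beyond the scatter), where a six-membered aromatic ring on the carbonyl carbon gave the lower number. Since compound 3 restores an aromatic ring at that carbonyl, a modest move back down is expected, about a 2.1-fold lower number from compound 2 to compound 3 (0.32 log units; beyond the scatter). Compound 3 is therefore estimated at 30 nM, with a likely range from 10 nM to 90 nM.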

Compound 3, inhibition constant: 1.8 nM
Compound 3: the middle estimate sits 17-fold (1.22 log units) above what was measured, and the stated range ends above it.
By their numbers in this assay, from the lowest: compound 3; then compound 1; then compound 2.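

At this carbonyl carbon, the choice of group matters far more than compounds 1 and 2 suggested: in this assay, 5-(trifluoromethyl)pyridin-3-yl gives a 35-fold lower number from compound 2 to compound 3 (1.54 log units; beyond the scatter) against 2,2,2-trifluoroethyl. Having a six-membered aromatic ring there is not the whole story, as replacing pyrimidin-5-yl with this group still gives a 14-fold lower number from compound 1 to compound 3 (1.15 log units; beyond the scatter) while keeping such a ring. Nothing available explains the size of these steps.
From the compounds shown here alone, whether the trifluoromethyl group or the ring nitrogen counts for more stays open. A plain pyridin-3-yl group and a phenyl ring carrying trifluoromethyl would separate the two.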